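Chloro step from compound 3 to compound 4

The source may report more compounds than this note shows. Statements on the series, on what has been measured and on what is new or still open speak of the compounds shown alone.

In a functional assay on KB cells (Homo sapiens) for cytotoxicity, read by MTT assay, with a stated time of 72 h (on this read-out higher numbers stand for weaker inhibition and lower numbers for stronger inhibition), compound 1 `O=S(=O)(c1ccccc1)c1nc2ccccc2nc1Nc1ccccc1` gives 22600 nM and compound 3 `Cc1ccc(S(=O)(=O)c2nc3ccccc3nc2Nc2ccccc2)cc1` gives 19000 nM in the same range: a 1.2-fold lower number from compound 1 to compound 3 (0.08 log units; within the scatter) stays within the scatter. Compound 2 `O=S(=O)(c1ccccc1)c1nc2ccccc2nc1Nc1ccc(F)cc1` reads > 50000 nM as a limit of the assay and not a number. Compound 4 `Cc1ccc(S(=O)(=O)c2nc3ccccc3nc2Nc2ccc(Cl)cc2)cc1` differs from compound 3 by chloro in place of hydrogen on an aromatic carbon with chloro in place of hydrogen on an aromatic carbon, para to a large group. The closest measured step is fluoro in place of hydrogen on an aromatic carbon, with an at least 2.2-fold higher number from compound 1 to compound 2 (0.34 log units; beyond the scatter) as its size. A step of similar size toward a higher number is therefore expected, though it rests on that single pair. The expected step is a 2.1-fold higher number from compound 3 to compound 4 (0.32 log units; beyond the scatter) on this estimate. In this assay the estimated value for compound 4 is 40000 nM with an expected range from 14000 nM to 50000 nM.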

Compound 4, half-maximal inhibitory concentration: 13800 nM
Estimate against measurement, compound 4: 2.9-fold (0.46 log units) above; measured number outside the range, below it.
By their numbers in this assay, from the lowest: compounds 4, 3 and 1 (each within the scatter of the next). At a limit, above all of these: compound 2.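

In this assay, chloro on the aromatic carbon para to a large group leaves the number within the scatter: a 1.4-fold lower number from compound 3 to compound 4 (0.14 log units; within the scatter). A halogen at this position therefore does not by itself move a compound out of this range, as the fluoro step alone had suggested. Compound 2 gives > 50000 nM, which is a limit of the assay and not a number: the limit of > 50000 nM in this assay, at which 1 of the 4 values shown sits.

The fluoro and chloro steps start from different compounds, so the two halogens are not compared on one background. On these data alone, what an amine or a carboxylic acid at this position would give stays open.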